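This account rests on a few compounds, and the source may have more. Where it says the series, first, only, none or still open, it means among the compounds named here.

Measured so far:
- compound 1 `CCCC(CCC)n1c(-c2ccc(OCc3c(-c4c(Cl)cccc4Cl)noc3C(C)C)cc2)nc2ccc(C(=O)O)cc21`: 1.8 nM
- compound 2 `CC(C)c1onc(-c2c(Cl)cccc2Cl)c1COc1ccc(-c2nc3ccc(C(=O)O)cc3n2C)c(Cl)c1`: 3.66 nM

In an assay on Huh-7 cells for agonist activity at Bile acid receptor (Homo sapiens), read by a luciferase reporter (a higher number here means that more compound is needed for the effect, a lower number that less compound is needed), compound 1 gives 1.8 nM, the lower of the two numbers recorded. Its nearest neighbour is compound 2, which in this assay gives 3.66 nM; the gap between the two lies beyond the scatter of repeated measurements. Within the data shown here, compound 2 also differs from compound 1 in more than one place, so no single step between measured compounds is available to calibrate the change that follows.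

Compound 3 `CC(C)c1onc(-c2c(Cl)cccc2Cl)c1COc1ccc(-c2nc3ccc(C(=O)O)cc3n2C(C)C)cc1` is the next member, not yet measured in this assay. It differs from compound 1 by isopropyl in place of 1-propylbutyl on an aromatic nitrogen. The series shows that a methyl on that nitrogen, combined with a further change elsewhere in compound 2, still leaves the number low. A shorter branched chain is therefore expected to keep compound 3 close to compound 1, with at most a modest upward step in the number.

For compound 3 the expected value in this assay is 3 nM, within 1.2 nM to 8 nM, a step of a 1.7-fold higher number from compound 1 to compound 3 (0.22 log units; within the scatter) that is expected to stay near the edge of the scatter.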

Compound 3, half-maximal effective concentration: 3.39 nM
Beside the measured number, compound 3's estimate is 1.1-fold (0.05 log units) below it, within the range that was stated.
By their numbers in this assay, from the lowest: compounds 1, 3 and 2 (each within the scatter of the next, the first and the last beyond it).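

The replacement of 1-propylbutyl by isopropyl on the aromatic nitrogen gives the series its first step in one place, and in this assay it reads a 1.9-fold higher number from compound 1 to compound 3 (0.27 log units; within the scatter) and so stays within the scatter. At this position the substituent can therefore shrink from 7 heavy atoms to 3, both all carbon, with no change that can be told from repeated measurement, something compound 2 could not show since it differs from compound 1 in more than one place. No measurement at hand bears on what lies behind this result.

Still open, as far as these compounds go, is whether the tolerance at this aromatic nitrogen extends to a cyclohexyl ring, a longer chain such as n-heptyl, or a chain carrying a polar group such as an amine or a hydroxyl. Also open, from the compounds shown here alone, is what a methyl on that nitrogen gives alone, since compound 2 carries it together with a further change, so the contribution of each of its two differences from compound 3 cannot be separated.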